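The source may report more compounds than this note shows. Statements on the series, on what has been measured and on what is new or still open speak of the compounds shown alone.

Measured compounds:
compound 1 `Cc1ccc(CS/C(=C/c2ccc(N(C)C)cc2)C(=O)c2ccc(Cl)cc2)cc1` gives > 100000 nM
compound 2 `Cc1ccc(CS/C(=C/c2c[nH]c3ccc(Cl)cc23)C(=O)c2ccc(Cl)cc2)cc1` gives 1000 nM
compound 3 `Cc1ccc(CS/C(=C/c2ccccc2F)C(=O)c2ccc(Cl)cc2)cc1` gives 10000 nM

In a functional assay on DU-145 cells (Homo sapiens) for inhibition, read by trypan blue exclusion, with a stated time of 96 h (a higher number here means a weaker inhibitor of growth, a lower number a stronger inhibitor of growth), compound 1 gives only a limit of the assay, not a number. Compound 1 therefore stands at the limit (the limit of > 100000 nM in this assay, at which 1 of the 3 values shown sits), the weakest point that can be read. Compound 4 `CN(C)c1ccc(/C=C(/SCc2ccc(F)cc2)C(=O)c2ccc(Cl)cc2)cc1` differs from compound 1 in one place: fluoro in place of methyl on an aromatic carbon. The measured steps all change a different part of the molecule, the aromatic group on the double-bonded chain carbon: an at least 100-fold lower number from compound 1 to compound 2 (2.00 log units; beyond the scatter), an at least 10-fold lower number from compound 1 to compound 3 (1.00 log units; beyond the scatter) and a 10-fold higher number from compound 2 to compound 3 (1.00 log units; beyond the scatter). Among the compounds with values here, none of them touches the (4-methylbenzyl)sulfanyl group, so no measured step bears directly on the change from compound 1 to compound 4. For compound 4 the expected step is therefore a step that the limit leaves unreadable from compound 1 to compound 4, nothing beyond the scatter. Compound 4 is estimated at 200000 nM, most likely again reported only as a limit. The expected range for compound 4 runs from 50000 nM to 1000000 nM.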

Compound 4, concentration for 50% growth inhibition: 50000 nM
Compound 4: middle estimate off by 4.0-fold (0.60 log units), on the high side; the measured number falls inside the stated range.
By their numbers in this assay, from the lowest: compound 2; then compound 3; then compound 4. At a limit, above all of these: compound 1.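

In this assay, (4-fluorobenzyl)sulfanyl in place of (4-methylbenzyl)sulfanyl is the first change shown away from the aromatic group on the double-bonded chain, and with 4-(dimethylamino)phenyl kept, it gives a compound with a readable number. Compound 1 gives > 100000 nM, which is a limit and not a number. Going by these compounds, the step reads an at least 2.0-fold lower number from compound 1 to compound 4 (0.30 log units; that floor lies within the scatter) and its true size stays unknown because one end of it is not a number: the limit of > 100000 nM in this assay, at which 1 of the 4 values shown sits.

On these data alone, it remains open whether the same swap shifts the number when the aromatic group is 5-chloro-1H-indol-3-yl or 2-fluorophenyl, where the starting compounds have readable values. Also open, as far as these compounds go, is what other groups on this same aromatic carbon, such as chloro, methoxy or an amine, would do.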